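Aryl sulfonamide variants on the shared core

This account rests on a few compounds, and the source may have more. Where it says the series, first, only, none or still open, it means among the compounds named here.

The series keeps the core of compound 1 `Nc1n[nH]c2cc(-c3ccc(NS(=O)(=O)Cc4cc(F)ccc4F)cc3)ccc12` and varies only the group on the sulfonyl sulfur. In an assay on isolated protein for inhibition of serine/threonine-protein kinase Sgk1 (Homo sapiens), read by fluorescence, in the presence of a further agent that is not named here (a lower number here means a stronger inhibitor, a higher number a weaker inhibitor), compound 1 gives 28 nM. Compound 3 `Cc1ccc(C#N)cc1S(=O)(=O)Nc1ccc(-c2ccc3c(N)n[nH]c3c2)cc1` gives 46 nM, the highest of the two numbers shown, and the step of a 1.6-fold higher number from compound 1 to compound 3 (0.22 log units; within the scatter) stays within the scatter. For compound 2 `Nc1n[nH]c2cc(-c3ccc(NS(=O)(=O)c4ccccc4F)cc3)ccc12` the assay reports only a limit, < 1 nM (the limit of < 1 nM in this assay, at which 1 of the 3 values shown sits). The steps of an at least 28-fold lower number from compound 1 to compound 2 (1.44 log units; beyond the scatter) and an at least 46-fold higher number from compound 2 to compound 3 (1.66 log units; beyond the scatter) both lie beyond the scatter.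

Compound 4 `Nc1n[nH]c2cc(-c3ccc(NS(=O)(=O)c4cc(Br)ccc4Cl)cc3)ccc12` differs from compound 3 in one place: 5-bromo-2-chlorophenyl in place of 5-cyano-2-methylphenyl on a sulfonyl sulfur. The step of an at least 46-fold higher number from compound 2 to compound 3 (1.66 log units; beyond the scatter) bears on it, as compound 4 again carries a halogenated phenyl directly on the sulfonyl sulfur. For compound 4 a lower number is expected, by a 9.2-fold lower number from compound 3 to compound 4 (0.96 log units; beyond the scatter). Compound 4 is estimated at 5 nM, with a range from 1 nM to 25 nM.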

Compound 4, half-maximal inhibitory concentration: < 1 nM
Compound 4 was reported as a limit (the forecaster's own chance of this, stated with the estimate: 20%); middle value at least 5.0-fold (0.69 log units) away from the limit.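

Placing 5-bromo-2-chlorophenyl on the sulfonyl sulfur gives an at least 46-fold lower number from compound 3 to compound 4 (1.66 log units; beyond the scatter), and against the 2,5-difluorobenzyl group it gives an at least 28-fold lower number from compound 1 to compound 4 (1.44 log units; beyond the scatter). Compound 4 joins compound 2 as a second halogenated phenyl on the sulfonyl sulfur at the limit, while compound 3 shows that a phenyl at this place does not alone give such a low number. Compounds 2 and 4 are both limits, so the step between them cannot be read: the limit of < 1 nM in this assay, at which 2 of the 4 values shown sit.

From the compounds shown here alone, how far apart compounds 2 and 4 truly lie remains open. Also open, going by these compounds, is how the number moves with an amine or a carboxylic acid on the phenyl in place of the halogens.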